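Chloro to methoxy on the aromatic ring

The source may report more compounds than this note shows. Statements on the series, on what has been measured and on what is new or still open speak of the compounds shown alone.

In a functional assay on SGC-7901 cells (Homo sapiens) for inhibition, read by MTT assay, with a stated time of 24 h (a lower number here means a stronger inhibitor, a higher number a weaker inhibitor), compound 3 (`CC1(C)[C@H]2CC[C@]1(C)N(Cc1cn(-c3ccccc3Cl)nn1)C(=O)C2`) gives 220 nM, compound 2 (`CC1(C)[C@H]2CC[C@]1(C)N(Cc1cn(-c3ccccc3C#N)nn1)C(=O)C2`) gives 260 nM and compound 1 (`CC1(C)[C@H]2CC[C@]1(C)N(Cc1cn(-c3ccccc3Br)nn1)C(=O)C2`) gives 500 nM. Compound 3 thus stands level with compound 2, as a 1.2-fold lower number from compound 2 to compound 3 (0.07 log units; within the scatter) lies within the scatter, while a 2.3-fold lower number from compound 1 to compound 3 (0.36 log units; beyond the scatter) is modest and a 1.9-fold lower number from compound 1 to compound 2 (0.28 log units; within the scatter) is again within the scatter. Compound 4 (`COc1ccccc1-n1cc(CN2C(=O)C[C@@H]3CC[C@@]2(C)C3(C)C)nn1`) carries methoxy in place of chloro on an aromatic carbon, ortho to a large group: methoxy in place of chloro on an aromatic carbon. Within the data shown here, no measured compound has methoxy there, so the only guide is these small swaps, and a step of similar modest size, leaning slightly upward, is expected: a 1.5-fold higher number from compound 3 to compound 4 (0.16 log units; within the scatter). Compound 4 is estimated at 320 nM, within an expected range of 130 nM to 800 nM.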

Compound 4, half-maximal inhibitory concentration: 280 nM
Compound 4: middle estimate off by 1.1-fold (0.06 log units), on the high side; low and high end bracket the measured number.
By their numbers in this assay, from the lowest: compounds 3, 2, 4 and 1 (each within the scatter of the next, the first and the last beyond it).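

In this assay, methoxy on this aromatic carbon, ortho to a large group, stays level with all three earlier compounds: a 1.3-fold higher number from compound 3 to compound 4 (0.10 log units; within the scatter), a 1.1-fold higher number from compound 2 to compound 4 (0.03 log units; within the scatter) and a 1.8-fold lower number from compound 1 to compound 4 (0.25 log units; within the scatter). The earlier compounds shown here carried only chloro, bromo or cyano here, so this shows that a two-heavy-atom group with a hydrogen-bond acceptor also enters without a step beyond the scatter. Among these compounds, the only such step at this place remains a 2.3-fold lower number from compound 1 to compound 3 (0.36 log units; beyond the scatter).

On these data alone, whether an amine, a carboxylic acid or a longer chain here would stay in this range remains open. No measurement shown here bears on what lies behind these numbers.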